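Swapping the aryl ring at the thiazole position of compound 3

The source may hold more compounds than are shown below. What is called first, only, known or untested is meant among the compounds shown, and "the series" means these compounds.

Compound 3 `O=C(O)Cc1sc(C(c2ccc(F)cc2)c2ccc(F)cc2)nc1-c1cc(F)nc(F)c1` gives 80% in an in vitro functional assay on HEK285-7 cells for antagonist activity at prostaglandin D2 receptor 2 (Homo sapiens), read by BRET and beta-arrestin recruitment (on this read-out higher numbers stand for larger maximal responses and lower numbers for smaller maximal responses), level with compound 1 `NS(=O)(=O)c1ccc(-c2nc(C(c3ccc(F)cc3)c3ccc(F)cc3)sc2CC(=O)O)cc1` at 80% and compound 2 `O=C(O)Cc1sc(C(c2ccc(F)cc2)c2ccc(F)cc2)nc1-c1ccnc(Cl)c1` at 80%. Compound 4 `O=C(O)Cc1sc(C(c2ccc(F)cc2)c2ccc(F)cc2)nc1-c1cc(F)cc(F)c1` carries one change from compound 3: 3,5-difluorophenyl in place of 2,6-difluoropyridin-4-yl on an aromatic carbon. Among the measured compounds shown here, three measured steps bear on it, all exchanging this same aryl ring: no change at the digits printed from compound 1 to compound 2 (within the scatter), no change at the digits printed from compound 1 to compound 3 (within the scatter) and no change at the digits printed from compound 2 to compound 3 (within the scatter); none of them moved the maximal response beyond the scatter. Because no change at the digits printed from compound 2 to compound 3 (within the scatter) already shows that a different ring at this position leaves the response flat, compound 4 is expected to behave alike. The step of no change at the digits printed from compound 3 to compound 4 (within the scatter) is therefore expected to be nil. Compound 4 is estimated at 80% in this assay, within 70% to 90%.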

Compound 4, largest response reached (reported as efficacy), in percent of the reference or control that the assay uses: 80%
For compound 4 middle estimate and measured number coincide at the digits printed; measured number inside the range.
By their numbers in this assay, from the lowest: compounds 1, 2, 3 and 4 (each within the scatter of the next).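

In this assay, removing the ring nitrogen leaves the maximal response flat (no change at the digits printed from compound 3 to compound 4 (within the scatter)), and the same holds against the chlorinated pyridine (no change at the digits printed from compound 2 to compound 4 (within the scatter)). The comparison with the 4-sulfamoylphenyl ring (no change at the digits printed from compound 1 to compound 4 (within the scatter)) shows that a carbon-only ring bearing just two fluorines serves here as well, so neither the sulfamoyl group nor a ring nitrogen is required for this response. No evidence at hand accounts for this flatness. The compounds shown leave open whether an unsubstituted phenyl, a morpholine or a simple methyl group at this position would also hold the response.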